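A few compounds are considered here, and "the series" means these few. Any claim that something is new, unique, unknown or untested is made for them only; others in the source may bear on it.

Of the compounds shown here, two have been measured so far. In an assay on CHO cells for displacement of a labelled ligand from adenosine receptor A1 (Homo sapiens), read by scintillation counting, with a stated time of 60 min, tested at 10 uM (a lower number here means less inhibition, a higher number more inhibition at the concentration tested (going by the name of the read-out)), compound 1 `N=c1oc2ccc(Br)cc2cc1C(=O)NCC(O)CO` gives 11%, while compound 2 `O=C(NC1CCCC1)c1cc2ccccc2oc1=O` gives 16%. Compound 1 has the lower of these two numbers, but the gap to compound 2 lies within the usual scatter of repeated measurements, so the two cannot be told apart on this evidence. Compound 3 `N=c1oc2ccc(Br)cc2cc1C(=O)NCCO` has not yet been measured. It differs from compound 1 in one place: hydrogen in place of hydroxymethyl on a saturated chain carbon bound to an oxygen on a saturated carbon and a saturated chain carbon. Among the compounds with values here, no step between measured compounds is available to show what such a change does. Because compound 1 already gives 11% in this assay, and the change is limited to the hydroxymethyl, no step beyond the scatter is expected in either direction. The expected step is a number 1 percentage points higher from compound 1 to compound 3 (within the scatter). Compound 3 is therefore estimated to give 12% in this assay, within a range from 0% to 28%.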

Compound 3, a percentage reported as inhibition, at one concentration (the size of the read-out at that concentration, not a potency): 26%
Compound 3: middle estimate off by 14 percentage points, on the low side; the measured number falls inside the stated range.
By their numbers in this assay, from the lowest: compounds 1, 2 and 3 (each within the scatter of the next, the first and the last beyond it).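

In this assay, within the data shown here, the change from 2,3-dihydroxypropyl to 2-hydroxyethyl, which puts hydrogen in place of hydroxymethyl, is a number 15 percentage points higher from compound 1 to compound 3 (beyond the scatter) and gives the first comparison here between compounds that differ in one place. It shows that this place on the chain is not indifferent to what sits there: with the core of compound 1 left unchanged, removing the hydroxymethyl alone moves the read-out by more than repeat measurements would. Nothing measured here gives a reason for the step.

Going by these compounds, whether an amine, a carboxylic acid or a longer chain in place of the hydroxymethyl would move the number further remains open. Compound 2 differs from compound 1 and compound 3 in more than one place, so this single pair cannot show whether the same change would act alike on another core.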